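A Second Core Receives the Same Aryl Swap

The compounds below may be only part of what the source reports. "The series", "measured", "known", "first", "only" and "open" are said of these compounds alone.

Measured compounds:
Compound 1 `COc1cccc(/C=C/C(=O)C(=Cc2ccc(O)c(F)c2)C(=O)/C=C/c2cccc(OC)c2OC)c1OC` gives 220 nM
Compound 2 `COc1cc(C=C(C(=O)/C=C/c2cccc(OC)c2OC)C(=O)/C=C/c2cccc(OC)c2OC)cc(OC)c1O` gives 210 nM
Compound 3 `COc1ccc(OC)c(/C=C/C(=O)C(=Cc2ccc(O)c(F)c2)C(=O)/C=C/c2cc(OC)ccc2OC)c1` gives 220 nM

All three compounds were tested in a functional assay on HepG2 cells (Homo sapiens) for antiproliferative activity, read by sulforhodamine B assay, with a stated time of 48 h; on this read-out lower numbers stand for stronger inhibition and higher numbers for weaker inhibition. Compound 1 and compound 2 share one core and differ in a single place: 4-hydroxy-3,5-dimethoxyphenyl in place of 3-fluoro-4-hydroxyphenyl on a double-bonded chain carbon bound to a double-bonded chain carbon. This change produced a 1.0-fold lower number from compound 1 to compound 2 (0.02 log units; within the scatter), so the two compounds cannot be told apart on this read-out.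

Compound 3 is built on a different core. Its structure and that of compound 1 contain the same atoms joined differently, and the difference between the two cores is not broken down here. In this assay compound 3 stands level with compound 1 at the digits given, and both sit within the scatter of compound 2, so no order can be drawn among the three.

Compound 4 `COc1ccc(OC)c(/C=C/C(=O)C(=Cc2cc(OC)c(O)c(OC)c2)C(=O)/C=C/c2cc(OC)ccc2OC)c1` has not yet been measured. It is compound 3 carrying the same change that turned compound 1 into compound 2: 4-hydroxy-3,5-dimethoxyphenyl in place of 3-fluoro-4-hydroxyphenyl on a double-bonded chain carbon bound to a double-bonded chain carbon. The place is described in the same words for both pairs, so this is the same change on a second core. Because the earlier instance gave a 1.0-fold lower number from compound 1 to compound 2 (0.02 log units; within the scatter), the step is expected to be a 1.0-fold lower number from compound 3 to compound 4 (0.01 log units; within the scatter). Compound 4 is therefore estimated at 215 nM, with an expected range from 110 nM to 430 nM. This rests on a single prior instance of the change and on compound 3 giving 220 nM.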

Compound 4, half-maximal inhibitory concentration: 210 nM
The estimate for compound 4 lay 1.0-fold (0.01 log units) above the measured number; low and high end bracket the measured number.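

In this assay, putting 4-hydroxy-3,5-dimethoxyphenyl in place of 3-fluoro-4-hydroxyphenyl on a double-bonded chain carbon bound to a double-bonded chain carbon gives a 1.0-fold lower number from compound 3 to compound 4 (0.02 log units; within the scatter), so this pair cannot be told apart on this read-out, and neither could the earlier pair on the other core. Set side by side, the two instances of the replacement agree: the same change on two cores in this assay, a 1.0-fold lower number (0.02 log units; within the scatter) from compound 1 to compound 2 and a 1.0-fold lower number (0.02 log units; within the scatter) from compound 3 to compound 4, 1.0-fold (0.00 log units) apart, within the scatter of two such steps. This shows that, for these two cores, the result seen on one core held on the other, but the agreement is between two steps that both lie within the scatter, so it shows no measurable effect being carried across and does not establish that the two groups are interchangeable on other cores or in other tests.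

On these data alone, both groups seen at this place are phenyl rings bearing a hydroxyl, so it remains open whether a phenyl ring bearing an amine or a carboxylic acid there would give a number that stands clear of the scatter. As far as these compounds go, it also remains open whether the agreement would hold on a third core, since two pairs are all that can be compared here.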